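The source may hold more compounds than are shown below. What is called first, only, known or untested is meant among the compounds shown, and "the series" means these compounds.

Compound 1 `CCCCC(Sc1ccc(OCCCOc2ccccc2OC)cc1)C(=O)O` gives in an assay on isolated protein for inhibition of Polyunsaturated fatty acid 5-lipoxygenase (Homo sapiens), read by HPLC, with a stated time of 15 min, in the presence of a further agent that is not named here (on this read-out lower numbers stand for stronger inhibition and higher numbers for weaker inhibition), a reading of > 10000 nM; this is a limit of the assay, not a number.
Compound 2 `CCCCC(Sc1ccc(OCCCOc2ccc(Cl)cc2OC)cc1)C(=O)O` gives in this assay a reading of > 10000 nM; this too is a limit, not a number.
Compound 3 `CCCCC(Sc1ccc(OCCCOc2cccc(C(F)(F)F)c2)cc1)C(=O)O` gives in this assay a reading of 1600 nM.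

For the measured compounds named here, compound 3 therefore holds the only genuine number among the three; the other two sit at the limit of > 10000 nM in this assay, at which 2 of the 3 values shown sit. Compound 4 `CCCCC(Sc1ccc(OCCCOc2cccc(C(C)C)c2)cc1)C(=O)O` differs from compound 3 by isopropyl in place of trifluoromethyl on an aromatic carbon. Going by the values given here, no measured step changes this group, so there is no direct precedent. The steps that do exist, an at least 6.2-fold lower number from compound 1 to compound 3 (0.79 log units; beyond the scatter) and an at least 6.2-fold lower number from compound 2 to compound 3 (0.79 log units; beyond the scatter), show that the 3-(trifluoromethyl)phenyl end gives a lower number than two methoxyphenyl ends, but both steps start from a limit, so their true size is not known. Nothing shows how much of that gain rests on the trifluoromethyl itself rather than on the rest of the ring. The expectation for compound 4 is therefore a number close to that of compound 3, with a 1.6-fold higher number from compound 3 to compound 4 (0.19 log units; within the scatter) as the estimated step, and with a real chance that only a limit is reported. Compound 4 is estimated at 2500 nM, with a range from 800 nM to 10000 nM.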

Compound 4, half-maximal inhibitory concentration: 1400 nM
Beside the measured number, compound 4's estimate is 1.8-fold (0.25 log units) above it; the range from low to high includes it.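

At this place, on an aromatic carbon meta to a large group, the change from trifluoromethyl to isopropyl leaves the reading in this assay unmoved: a 1.1-fold lower number from compound 3 to compound 4 (0.06 log units; within the scatter). The earlier compounds shown here could not separate the trifluoromethyl from the rest of the ring, but now an end carrying no fluorine at all also gives a lower number than both methoxyphenyl ends, with an at least 7.1-fold lower number from compound 2 to compound 4 (0.85 log units; beyond the scatter) and an at least 7.1-fold lower number from compound 1 to compound 4 (0.85 log units; beyond the scatter), so the gain does not depend on the fluorine atoms. Those two steps give only a lower bound on their size, since compound 1 and compound 2 each stand at a limit rather than a number: the limit of > 10000 nM in this assay, at which 2 of the 4 values shown sit.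

Still open, going by these compounds, is whether this place accepts groups of a quite different kind, such as an amine, a carboxylic acid or a longer chain, or only carbon-rich groups like these two. Also open, on these data alone, is how a plain phenyl end, with hydrogen at this place, would read, and so whether either group adds anything over the bare ring.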